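The source may hold more compounds than are shown below. What is called first, only, known or untested is meant among the compounds shown, and "the series" means these compounds.

In a functional assay on MDA-MB-231 cells (Homo sapiens) for inhibition, read by MTT assay, with a stated time of 48 h (a higher number here means a weaker inhibitor, a lower number a stronger inhibitor), compounds built on one shared core differ only in the group on an amide-type nitrogen. Compound 1 `N#Cc1ccccc1NC(=O)c1[nH]cnc1-c1nc2ccccc2[nH]1` gives 34200 nM, compound 2 `N#Cc1cccc(NC(=O)c2[nH]cnc2-c2nc3ccccc3[nH]2)c1` gives 24900 nM and compound 3 `O=C(NC1CC1)c1[nH]cnc1-c1nc2ccccc2[nH]1` gives 35200 nM. Compound 3 thus stands level with the other two, within the scatter of both.

Compound 4 `O=C(NCC1CC1)c1[nH]cnc1-c1nc2ccccc2[nH]1` carries cyclopropylmethyl in place of the cyclopropyl of compound 3, on the same amide-type nitrogen: cyclopropylmethyl in place of cyclopropyl on an amide-type nitrogen. This exact change has not been measured, but three steps at that nitrogen bear on it. They are a 1.4-fold lower number from compound 1 to compound 2 (0.14 log units; within the scatter), a 1.0-fold higher number from compound 1 to compound 3 (0.01 log units; within the scatter) and a 1.4-fold higher number from compound 2 to compound 3 (0.15 log units; within the scatter), and all of them lie within the scatter. Even exchanging a cyanophenyl group for cyclopropyl left the number unchanged beyond the scatter, so the smaller exchange here is expected to do the same. The expected step is a 1.1-fold lower number from compound 3 to compound 4 (0.04 log units; within the scatter), which would be none beyond the scatter. For compound 4 the estimated value is 32000 nM, with an expected range of 17000 nM to 60000 nM.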

Compound 4, half-maximal inhibitory concentration: 33100 nM
Beside the measured number, compound 4's estimate is 1.0-fold (0.01 log units) below it; the range from low to high includes it.
By their numbers in this assay, from the lowest: compounds 2, 4, 1 and 3 (each within the scatter of the next).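

In this assay, a fourth group on the amide-type nitrogen behaves like the other three, with a 1.1-fold lower number from compound 3 to compound 4 (0.03 log units; within the scatter), a 1.3-fold higher number from compound 2 to compound 4 (0.12 log units; within the scatter) and a 1.0-fold lower number from compound 1 to compound 4 (0.01 log units; within the scatter). The earlier compounds had shown only that cyclopropyl and the two cyanophenyl groups could not be told apart at this nitrogen, and cyclopropylmethyl now joins them, so the exchange of cyclopropyl for cyclopropylmethyl leaves the number unchanged beyond the scatter. Nothing available offers an explanation for this flat picture.

From the compounds shown here alone, whether any group at this nitrogen can move the number beyond the scatter remains open. Going by these compounds, an amine, a carboxylic acid or a longer chain in this place could test that, and the effect of changes to the shared core also remains unknown.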